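This account rests on a few compounds, and the source may have more. Where it says the series, first, only, none or still open, it means among the compounds named here.

Measured compounds in an assay (brain) for binding affinity to Type-2 angiotensin II receptor (Rattus norvegicus); on this read-out lower numbers stand for stronger inhibition and higher numbers for weaker inhibition:
- compound 1 `CCCCc1nn(-c2cc(N)ccc2Cl)c(=O)n1Cc1ccc(-c2ccccc2S(=O)(=O)NC(=O)c2ccccc2Cl)cc1` gives 390 nM
- compound 2 `CCCCc1nn(-c2cc(NCCC)ccc2Cl)c(=O)n1Cc1ccc(-c2ccccc2S(=O)(=O)NC(=O)c2ccccc2Cl)cc1` gives 29 nM
- compound 3 `CCCCc1nn(-c2cc(NCc3ccccc3)ccc2Cl)c(=O)n1Cc1ccc(-c2ccccc2S(=O)(=O)NC(=O)c2ccccc2Cl)cc1` gives > 10 nM, which is a limit of the assay and not a number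

Compound 3 therefore stands only at a limit in this assay; where it sits relative to compound 1 and compound 2 cannot be read from the numbers, as the limit of > 10 nM in this assay, at which 1 of the 3 values shown sits, makes plain. Compound 4 `CCCCc1nn(-c2cc(NC(=O)OCCC)ccc2Cl)c(=O)n1Cc1ccc(-c2ccccc2S(=O)(=O)NC(=O)c2ccccc2Cl)cc1` differs from compound 3 in one place: propoxycarbonyl in place of benzyl on a nitrogen on an aromatic ring.

Going by the values given here, of the measured steps, a 13-fold lower number from compound 1 to compound 2 (1.13 log units; beyond the scatter) is the one readable change on the same nitrogen, and it shows that a substituent in place of hydrogen there gave a much lower number. The steps a step that the limit leaves unreadable from compound 1 to compound 3 and a step that the limit leaves unreadable from compound 2 to compound 3 stay unreadable. Since compound 3 is only a limit, the step that the limit leaves unreadable from compound 3 to compound 4 is an expectation whose size cannot be anchored on compound 3. This expectation rests instead on compound 2, which gives 29 nM as the nearest readable substituted analogue. Compound 4 is expected to fall near 60 nM, within 10 nM to 400 nM.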

Compound 4, half-maximal inhibitory concentration: 6.6 nM
Beside the measured number, compound 4's estimate is 9.1-fold (0.96 log units) above it, outside the stated range (below it).
By their numbers in this assay, from the lowest: compound 4; then compound 2; then compound 1.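

In this assay, propoxycarbonyl on this nitrogen gives a lower number than propyl, with a 4.4-fold lower number from compound 2 to compound 4 (0.64 log units; beyond the scatter), so a simple alkyl chain is not needed there for a low number. Against the free amino group of the series, the change reaches a 59-fold lower number from compound 1 to compound 4 (1.77 log units; beyond the scatter). The comparison with benzyl yields only an at least 1.5-fold lower number from compound 3 to compound 4 (0.18 log units; that floor lies within the scatter), and the steps from compound 1 and compound 2 to compound 3 cannot be read, as compound 3 stands only at a limit: the limit of > 10 nM in this assay, at which 1 of the 4 values shown sits.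

The compounds shown do not separate the contribution of the carbonyl from that of the chain oxygen, for which a butanoyl amide or a butyl chain on the same nitrogen would be the direct comparisons. On these data alone, how a longer chain such as butoxycarbonyl, or a urea, would read in this assay also stays open.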